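Halogen exchange on two cores, whole-animal read-out

The compounds below may be only part of what the source reports. "The series", "measured", "known", "first", "only" and "open" are said of these compounds alone.

Compound 1 `O=c1c(-c2nn[nH]n2)c[nH]c2ccc(Cl)cc12` and compound 2 `O=c1c(-c2nn[nH]n2)c[nH]c2ccc(F)cc12` share one core; compound 3 `O=C(O)c1cnc2c(Cl)cccc2c1` and compound 4 `O=C(O)c1cnc2c(F)cccc2c1` share another, and the difference between the two cores is not broken down here. In a functional assay on the whole organism (strain Sprague-Dawley) for inhibition, with Rattus norvegicus as the target (on this read-out lower numbers stand for an effect already at smaller amounts and higher numbers for an effect only at larger amounts of compound), compound 1 reaches only a limit, > 25 mg/kg. In this assay compound 2 likewise reaches only a limit, > 20 mg/kg. The change between them is fluoro in place of chloro on an aromatic carbon, and the step that the two limits leave unreadable from compound 1 to compound 2 cannot be read, because the limit of > 25 mg/kg in this assay, at which 1 of the 3 values shown sits, and the limit of > 20 mg/kg in this assay, at which 1 of the 3 values shown sits, bound both of its ends. In this assay, among the compounds with values here, compound 3 gives 150 mg/kg, the only number in the set. Compound 4 differs from compound 3 by fluoro in place of chloro on an aromatic carbon. This is the same kind of change as between compound 1 and compound 2, though the surroundings differ: ortho to a fused ring and meta to a fused ring in compound 4, against meta to a fused ring and para to a fused ring in compound 2. With the measured step unreadable, nothing shown fixes the size of the next one. The step of no change at the digits printed from compound 3 to compound 4 (within the scatter) is estimated to stay within the usual scatter, resting on compound 3 at 150 mg/kg alone. Compound 4 is therefore expected near 150 mg/kg, between 60 mg/kg and 400 mg/kg.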

Compound 4, minimum effective dose: 150 mg/kg
For compound 4 middle estimate and measured number coincide at the digits printed, and the stated range covers the measured number.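

In this assay, fluoro in place of chloro on an aromatic carbon gives no change at the digits printed from compound 3 to compound 4 (within the scatter), so on the core of compound 3 this exchange, ortho to a fused ring and meta to a fused ring, leaves the read-out within the scatter. Compound 1 and compound 2 each stand only at a limit, so the same exchange on their core cannot be read, and this single step does not show that the result carries from one core to the other in either direction. Nothing shown accounts for why the exchange on the core of compound 3 leaves the read-out within the scatter.

Open, on these data alone, is whether a group other than these two halogens at the same place, such as methoxy or an amine, would move the read-out on the core of compound 3. Also open, as far as these compounds go, is how the read-out responds when a primary amide takes the place of the carboxylic acid of compound 3.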